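Three near-identical read-outs and a carboxylic acid swap

The compounds below may be only part of what the source reports. "The series", "measured", "known", "first", "only" and "open" are said of these compounds alone.

The study compares three measured compounds and one not yet measured in a functional assay on the whole organism (Tail, strain ICR) with Mus musculus as the target, in the tail flick test, with a stated time of 60 min, at a dose of 25 umol/kg by the oral route; on this read-out higher numbers stand for a stronger effect at the one dose given and lower numbers for a weaker effect. Compound 1, `O=C(CN(c1ncnc2c1ncn2C1CCCCO1)C1CC1)N[C@@H](CCC(=O)OCc1ccccc1)C(=O)OCc1ccccc1`, gives 34.7% in this assay. Compound 2, `CC[C@H](C)[C@H](NC(=O)CN(c1nc(Cl)nc2[nH]cnc12)C1CC1)C(=O)O`, gives 36%. Compound 3, `O=C(OCc1ccccc1)[C@@H]1CCCN1C(=O)CN(c1ncnc2c1ncn2C1CCCCO1)C1CC1`, gives 36.7%. Among the compounds with values here, all three numbers lie within the scatter of one another: the value of compound 2 is nearest to that of compound 3 and furthest from that of compound 1, yet both gaps are within the scatter, so no compound can be called more or less active than another on these data.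

The step of interest leads from compound 2 to compound 4, `O=C(O)CC[C@H](NC(=O)CN(c1nc(Cl)nc2[nH]cnc12)C1CC1)C(=O)O`. The change is 2-carboxyethyl in place of sec-butyl on a saturated chain carbon bound to an amide-type nitrogen and a carbonyl carbon. Within the data shown here, no step between two measured compounds that differ in one place is available, so nothing in the measured set tells how the read-out in this assay responds to such a change.

With three values that do not separate from each other, the author expects the step of a number 1 percentage points lower from compound 2 to compound 4 (within the scatter) to stay within the scatter, with no direction to be read from it. Compound 4 is therefore estimated at 35%, with a range from 20% to 50%.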

Compound 4, a percentage reported as activity, at one dose (the size of the read-out at that dose, not a potency): 33.3%
For compound 4 the middle estimate is 1.7 percentage points above the measured one, within the range that was stated.
By their numbers in this assay, from the lowest: compounds 4, 1, 2 and 3 (each within the scatter of the next).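

In this assay, within the data shown here, the change from sec-butyl to 2-carboxyethyl on a saturated chain carbon bound to an amide-type nitrogen and a carbonyl carbon supplies the first step in one place, a number 2.7 percentage points lower from compound 2 to compound 4 (within the scatter), so the read-out does not separate the two compounds at the one dose given. Among these compounds, at this position, then, a group with no hydrogen-bond donor or acceptor and one with a hydrogen-bond donor, a hydrogen-bond acceptor and a double bond outside aromatic rings give read-outs that cannot be told apart, something the earlier compounds, which offered no such step, could not show. Nothing available explains this outcome.

Going by these compounds, what remains open is whether the read-out at this position would also stay within the scatter with a primary amine on the chain, such as a 4-aminobutyl group, or with a phenyl ring or a longer unbranched alkyl chain in place of sec-butyl. Equally open, on these data alone, is whether compound 2 and compound 4 would stay together at other doses or times, since this single step rests on one dose and one stated time.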